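From isopropyl to isobutyl on the ester

This account rests on a few compounds, and the source may have more. Where it says the series, first, only, none or still open, it means among the compounds named here.

Measured so far in a functional assay on the whole organism with Scenedesmus acutus as the target; on this read-out higher numbers stand for weaker inhibition and lower numbers for stronger inhibition:
compound 1 `O=C1C2=C(CCCC2)C(=O)N1c1ccc(Cl)cc1F` gives 24.6 nM
compound 2 `CCOC(=O)c1cc(N2C(=O)C3=C(CCCC3)C2=O)c(F)cc1Cl` gives 100 nM
compound 3 `CC(C)OC(=O)c1cc(N2C(=O)C3=C(CCCC3)C2=O)c(F)cc1Cl` gives 57.5 nM

Compound 3, at 57.5 nM, cannot be told apart from compound 2, but its inhibition is weaker than that of compound 1. Compound 4 `CC(C)COC(=O)c1cc(N2C(=O)C3=C(CCCC3)C2=O)c(F)cc1Cl` has not yet been measured. It differs from compound 3 at the end of the ester chain: isobutyl in place of isopropyl on an oxygen next to a carbonyl group. This places isobutyl in place of isopropyl on an oxygen next to a carbonyl group.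

Among the measured compounds shown here, the closest guide is the only measured change within that chain, a 1.7-fold lower number from compound 2 to compound 3 (0.24 log units; within the scatter). The larger steps, a 4.1-fold higher number from compound 1 to compound 2 (0.61 log units; beyond the scatter) and a 2.3-fold higher number from compound 1 to compound 3 (0.37 log units; beyond the scatter), each add a whole ester group, which is a different kind of change. No step beyond the scatter is therefore expected in this assay, although a single comparison is thin evidence. The estimated change is a 1.2-fold higher number from compound 3 to compound 4 (0.09 log units; within the scatter). For compound 4, the expected value is 70 nM, with an estimated range of 30 nM to 160 nM.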

Compound 4, half-maximal inhibitory concentration: 33.1 nM
Estimate against measurement, compound 4: 2.1-fold (0.33 log units) above; the range from low to high includes it.
By their numbers in this assay, from the lowest: compounds 1, 4, 3 and 2 (each within the scatter of the next, the first and the last beyond it).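

In this assay, among the compounds shown here, isobutyl in place of isopropyl on this ester oxygen gives no step that can be told from the scatter (a 1.7-fold lower number from compound 3 to compound 4 (0.24 log units; within the scatter)). Taken from the ethyl ester, however, the chain now gives the first change within it that clears the scatter (a 3.0-fold lower number from compound 2 to compound 4 (0.48 log units; beyond the scatter)), even though neither the ethyl-to-isopropyl step nor the isopropyl-to-isobutyl step does so alone. Unlike the ethyl and isopropyl esters, the isobutoxycarbonyl compound also cannot be told apart from compound 1, which has hydrogen at that aromatic carbon (a 1.3-fold higher number from compound 1 to compound 4 (0.13 log units; within the scatter)), and no measurement here accounts for any of this.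

As far as these compounds go, whether a straight butyl chain would match the branched isobutyl remains open. So does what a longer chain, a benzyl group or a free carboxylic acid would do at this place.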